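The compounds below may be only part of what the source reports. "The series", "measured", "known", "first", "only" and "open" are said of these compounds alone.

Measured compounds and their values:
Compound 1 `COc1ccc(C(=O)CCN2CCN(c3ccc(F)cc3)CC2)cc1` gives 55000 nM
Compound 2 `O=C(CCN1CCN(c2ccc(F)cc2)CC1)c1ccc(F)c(Cl)c1` gives 185000 nM

Both values come from an ADME assay on Vero cells (Chlorocebus sabaeus) for cytotoxicity, read by resazurin assay, with a stated time of 72 h (on this read-out lower numbers stand for stronger inhibition and higher numbers for weaker inhibition), and, of the two, compound 2 holds the higher number. Two values show no pattern, but they do mark out the range seen so far.

The next compound to be tested is compound 3 `O=C(CCN1CCN(c2ccc(F)cc2)CC1)c1ccc(Cl)c(F)c1`, which has the same atoms as compound 2, joined differently. The change is 4-chloro-3-fluorophenyl in place of 3-chloro-4-fluorophenyl on a carbonyl carbon and it sits on a carbonyl carbon, where 4-chloro-3-fluorophenyl takes the place of 3-chloro-4-fluorophenyl.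

Within the data shown here, only one measured step bears on this, a modest one beyond the scatter: a 3.4-fold higher number from compound 1 to compound 2 (0.53 log units; beyond the scatter) (the swap there replaced 4-methoxyphenyl, a different group). Among the measured compounds shown here, no measured step shows what exchanging these two closely related groups does, so no direction can be argued with any confidence. The expected result is therefore no step beyond the scatter, an estimated 1.2-fold lower number from compound 2 to compound 3 (0.06 log units; within the scatter) in this assay. The estimated value for compound 3 is 160000 nM (expected range 75000 nM to 340000 nM).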

Compound 3, half-maximal inhibitory concentration: 105000 nM
Compound 3: middle estimate off by 1.5-fold (0.18 log units), on the high side; low and high end bracket the measured number.
By their numbers in this assay, from the lowest: compounds 1, 3 and 2 (each within the scatter of the next, the first and the last beyond it).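

In this assay, putting 4-chloro-3-fluorophenyl in place of 3-chloro-4-fluorophenyl on a carbonyl carbon gives a 1.8-fold lower number from compound 2 to compound 3 (0.25 log units; within the scatter) and so, for this pair of groups built from the same atoms, the exchange cannot be told apart from ordinary repeat variation. Putting 4-chloro-3-fluorophenyl in place of 4-methoxyphenyl at the same place gives a 1.9-fold higher number from compound 1 to compound 3 (0.28 log units; within the scatter) and therefore does not repeat the step beyond the scatter seen earlier, a 3.4-fold higher number from compound 1 to compound 2 (0.53 log units; beyond the scatter), which means that the earlier step cannot be read as a general result of replacing 4-methoxyphenyl with a chlorine- and fluorine-bearing phenyl group. No other measurement is available here that could explain these numbers.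

Still open, as far as these compounds go, is whether a quite different group on this carbonyl carbon, such as a carboxylic acid, an amine or a plain phenyl, would move the number well outside the range spanned by these three compounds. Also open, from the compounds shown here alone, is what a change elsewhere in the shared core would do, as all three compounds differ only at this one place.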